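The source may hold more compounds than are shown below. What is called first, only, known or untested is meant among the compounds shown, and "the series" means these compounds.

Of the compounds shown here, three built on one shared core have been tested in a functional assay on MCF7 cells (Homo sapiens) for antiproliferative activity, read by MTT assay, with a stated time of 24 h; on this read-out higher numbers stand for weaker inhibition and lower numbers for stronger inhibition. Compound 1 `c1ccc(C2=NN(c3ccc(-c4ccccc4)nn3)C(c3ccccc3)C2)cc1` gives 23800 nM. Compound 2 `COc1ccc(C2CC(c3ccccc3)=NN2c2ccc(-c3ccccc3)nn2)cc1` differs from it by methoxy in place of hydrogen on an aromatic carbon, and in this assay compound 2 gives 100000 nM; the step is a 4.2-fold higher number from compound 1 to compound 2 (0.62 log units; beyond the scatter). Compound 3 `COc1ccc(C2CC(c3ccc(Cl)cc3)=NN2c2ccc(-c3ccccc3)nn2)cc1` adds a chloro group, and in this assay compound 3 gives 100000 nM; the step is no change at the digits printed from compound 2 to compound 3 (within the scatter), so compound 2 and compound 3 sit level with each other and both stand well apart from compound 1. The difference between compound 3 and compound 1 is not broken down here.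

Compound 4 `COc1ccc(C2CC(c3ccc(Cl)cc3)=NN2c2ccc(-c3ccccc3)nn2)c(OC)c1` has not been measured. It differs from compound 3 by methoxy in place of hydrogen on an aromatic carbon. This is the same kind of change that turned compound 1 into compound 2, though not the same: in that earlier case the methoxy group entered para to a large group, whereas here it enters ortho to a large group and meta to a methoxy group that is already present.

The expected change in this step is no change at the digits printed from compound 3 to compound 4 (within the scatter). This rests on the earlier methoxy step a 4.2-fold higher number from compound 1 to compound 2 (0.62 log units; beyond the scatter), tempered by the observation that compound 2 and compound 3 already share the weakest value seen in this series, so little room for a further rise in the number is apparent from these data alone. In this assay compound 4 is therefore expected to give about 100000 nM, most likely between 40000 nM and 250000 nM.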

Compound 4, half-maximal inhibitory concentration: > 100000 nM
Compound 4: only a limit was reported (the forecaster's own chance of this, stated with the estimate: 40%); the middle value lies on the limit itself.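

In this assay, compound 4 gives > 100000 nM, which is a limit of the assay and not an exact number. The added methoxy group, which turns 4-methoxyphenyl into 2,4-dimethoxyphenyl, gives a number no lower from compound 3 to compound 4 (the limit leaves the size open), so the result shows no drop in the number on this second core, but it cannot tell how large any rise was, or whether there was one at all. Carrying the change across is therefore consistent with the earlier methoxy step in that neither step lowers the number, yet this falls short of showing that the change has the same size on both cores: the same change on two cores in this assay, a 4.2-fold higher number (0.62 log units; beyond the scatter) from compound 1 to compound 2 and a number no lower (the limit leaves the size open) from compound 3 to compound 4; the limit leaves it open whether they differ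

The compounds shown leave open how a hydroxyl group, an amine or a carboxylic acid would read in place of the new methoxy group. They also leave open how a methoxy group placed ortho to a large group would read on a compound that carries no other methoxy group, such as compound 1, where a measured number might show the size of the step that the limit on compound 4 conceals.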